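Trifluoromethyl added to the phenyl of a lactam series

This account rests on a few compounds, and the source may have more. Where it says the series, first, only, none or still open, it means among the compounds named here.

Compound 3 `O=C1C=CCC(/C=C/c2ccccc2)N1` is a lactam carrying a styryl group; in a functional assay on U-251 cells (Homo sapiens) for inhibition, read by sulforhodamine B assay, with a stated time of 48 h (a lower number here means a stronger inhibitor of growth, a higher number a weaker inhibitor of growth), compound 3 gives 798 uM, the highest number of the three measured compounds. The nearest is compound 1 `COc1ccc(/C=C/C2CC(=O)C=CO2)cc1`, whose value in this assay is 152 uM, lower by a step beyond the scatter. Compound 2 `COc1ccc(/C=C/C2CC=CC(=O)O2)c(OC)c1` lies furthest away, with 4.6 uM in this assay. Compound 4 `O=C1C=CCC(/C=C/c2ccccc2C(F)(F)F)N1` differs from compound 3 by trifluoromethyl in place of hydrogen on an aromatic carbon. For the measured compounds named here, no measured pair shows this change, so the expectation rests on the general spread only. A small downward step is expected, possibly within the scatter, estimated as a 2.0-fold lower number from compound 3 to compound 4 (0.30 log units; within the scatter). For compound 4 the expected value in this assay is 400 uM, within 130 uM to 1200 uM.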

Compound 4, concentration for growth inhibition (reported as GI): 69.9 uM
Beside the measured number, compound 4's estimate is 5.7-fold (0.76 log units) above it, and the stated range ends above it.
By their numbers in this assay, from the lowest: compound 2; then compound 4; then compound 1; then compound 3.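

Trifluoromethyl in place of hydrogen on this aromatic carbon gives an 11-fold lower number from compound 3 to compound 4 (1.06 log units; beyond the scatter) in this assay, so a single change at this position can move growth inhibition well beyond the scatter. For the compounds shown here, this is the only one-place comparison among the four compounds, as compound 1 and compound 2 each differ from compound 3 in more than one place. Nothing measured here explains the drop in the number.

On these data alone, whether a methyl group or a chlorine atom on the same carbon would give a similar step remains open. So does the effect of trifluoromethyl on other carbons of the ring.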